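The source may hold more compounds than are shown below. What is called first, only, known or untested is meant among the compounds shown, and "the series" means these compounds.

Three amides sharing one core have been measured in a functional assay on PC-3 cells (Homo sapiens) for antiproliferative activity, read by MTT assay, with a stated time of 72 h; a lower number here means a stronger inhibitor, a higher number a weaker inhibitor. Compound 1 `CCn1cc(C(CC)(CC)c2ccc(C#CC(O)(CC)CC)c(C)c2)cc1C(=O)NCC(=O)OC`, a methyl ester, gives 17500 nM, compound 2 `CCn1cc(C(CC)(CC)c2ccc(C#CC(O)(CC)CC)c(C)c2)cc1C(=O)NCCCN(C)C` gives 15100 nM, and compound 3 `CCn1cc(C(CC)(CC)c2ccc(C#CC(O)(CC)CC)c(C)c2)cc1C(=O)NCC(=O)O`, which carries a free carboxy group, gives 6300 nM. That is the lowest of the three numbers, so compound 3 is the strongest inhibitor of this small set.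

The next compound is compound 4 `CCn1cc(C(CC)(CC)c2ccc(C#CC(O)(CC)CC)c(C)c2)cc1C(=O)N[C@@H](C)CO`, and its difference from compound 3 lies in the amide side chain: 1-(hydroxymethyl)ethyl in place of carboxymethyl on an amide-type nitrogen. Put simply, 1-(hydroxymethyl)ethyl stands in place of carboxymethyl on an amide-type nitrogen, so the carboxy group is lost.

Among the measured compounds shown here, three measured steps bear on this change. Exchanging one side chain without a carboxy group for another gave a 1.2-fold lower number from compound 1 to compound 2 (0.06 log units; within the scatter). Moving to the carboxy group gave a 2.8-fold lower number from compound 1 to compound 3 (0.44 log units; beyond the scatter) and a 2.4-fold lower number from compound 2 to compound 3 (0.38 log units; beyond the scatter), both modest. For the measured compounds named here, compound 4 also lacks the carboxy group, so it may drift back towards compound 1 and compound 2, although no measured compound carries its side chain.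

The expected change in this assay is a small move towards a higher number, a 1.7-fold higher number from compound 3 to compound 4 (0.24 log units; within the scatter). The estimated value for compound 4 is 11000 nM, with an expected range from 5000 nM to 25000 nM.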

Compound 4, half-maximal inhibitory concentration: 6050 nM
For compound 4 the middle estimate is 1.8-fold (0.26 log units) above the measured one; the measured number falls inside the stated range.
By their numbers in this assay, from the lowest: compounds 4 and 3 (each within the scatter of the next); then compounds 2 and 1 (each within the scatter of the next).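

In this assay, the carboxy group turns out not to be needed for the lowest numbers in this set: replacing carboxymethyl with 1-(hydroxymethyl)ethyl on the amide-type nitrogen gives a 1.0-fold lower number from compound 3 to compound 4 (0.02 log units; within the scatter) and removes the carboxy group without any change beyond the scatter. The side chains without a carboxy group also do not behave alike, as 1-(hydroxymethyl)ethyl gives a 2.5-fold lower number from compound 2 to compound 4 (0.40 log units; beyond the scatter) in place of 3-(dimethylamino)propyl and a 2.9-fold lower number from compound 1 to compound 4 (0.46 log units; beyond the scatter) in place of (methoxycarbonyl)methyl, both modest steps. The link between a free carboxy group and a lower number, suggested by the first three compounds, therefore does not hold for compound 4, and no measurement here explains this result.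

The compounds shown leave open whether the hydroxy group or the methyl group of the new side chain matters, which a plain 2-hydroxyethyl or isopropyl group on the same nitrogen would help to separate. They also leave open how the mirror-image form of compound 4 or a longer chain such as 3-hydroxypropyl would compare.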